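Swapping the amide end of a bis-sulfonamide piperidine

A few compounds are considered here, and "the series" means these few. Any claim that something is new, unique, unknown or untested is made for them only; others in the source may bear on it.

Two compounds share a core in which a benzene bearing two sulfonamides is linked to a piperidine carrying a carboxamide. Compound 1 `CCN(CC)S(=O)(=O)c1ccc(S(=O)(=O)N2CCC[C@@H](C(=O)NC3COC3)C2)cc1` gives 13800 nM in a functional assay on BXPC-3 cells (Homo sapiens) for inhibition, read by MTT assay, with a stated time of 7 days (on this read-out lower numbers stand for stronger inhibition and higher numbers for weaker inhibition), the highest number of the two measured, a weaker result than compound 2 `CN(C)S(=O)(=O)c1ccc(S(=O)(=O)N2CCC[C@@H](C(=O)N3CCC(F)(F)CC3)C2)cc1`, which gives 560 nM in this assay, a difference beyond the usual scatter.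

Compound 3 `CCN(CC)S(=O)(=O)c1ccc(S(=O)(=O)N2CCC[C@@H](C(=O)N3CCC(C(F)F)CC3)C2)cc1` has not yet been measured. It differs from compound 1 in one place: 4-(difluoromethyl)piperidin-1-yl in place of (oxetan-3-yl)amino on a carbonyl carbon. Since compound 2 pairs a fluorinated piperidinyl amide with a result of 560 nM, a move in the same direction is expected here, though the other sulfonamide still matches compound 1. The step from compound 1 to compound 3 in this assay is expected to be a 12-fold lower number from compound 1 to compound 3 (1.06 log units; beyond the scatter), toward a lower number. Compound 3 is therefore estimated at 1200 nM, with a range from 300 nM to 5000 nM.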

Compound 3, half-maximal inhibitory concentration: 450 nM
The estimate for compound 3 lay 2.7-fold (0.43 log units) above the measured number, within the range that was stated.
By their numbers in this assay, from the lowest: compounds 3 and 2 (each within the scatter of the next); then compound 1.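

With the rest of the molecule unchanged, exchanging only the group on the amide carbonyl gives, in this assay, a 31-fold lower number from compound 1 to compound 3 (1.49 log units; beyond the scatter), so the group at this position alone can change the result by a large margin. Compound 1 and compound 2 differ at both the amide end and the other sulfonamide, so that earlier pair could not isolate this position. The change replaces 5 heavy atoms with 9 and removes 1 hydrogen-bond donor and 1 hydrogen-bond acceptor, and no available measurement shows which of these differences matters.

The compounds shown leave open whether the fluorine atoms are needed, which an unsubstituted piperidin-1-yl or a 4-methylpiperidin-1-yl group could test. They also leave open whether a ring is needed at all, which an open-chain diethylamino group could test.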